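From a Methylphenyl Group to a Furan Ring

The source may report more compounds than this note shows. Statements on the series, on what has been measured and on what is new or still open speak of the compounds shown alone.

Measured so far:
Compound 1, `Cc1cc(-c2ccc(C(F)(F)F)cc2)nn1S(=O)(=O)Oc1ccccc1`: 35.9%
Compound 2, `Cc1cccc(-c2cc(C)n(S(=O)(=O)Oc3ccccc3)n2)c1`: 8.7%

In a functional assay on the whole organism for inhibition, with Mus musculus as the target, with stated times of 3 days and 30 min, at a dose of 30 mg/kg by the oral route (a lower number here means less inhibition, a higher number more inhibition at the dose given (going by the name of the read-out)), compound 1 gives 35.9%, while compound 2 gives 8.7%, the lower of the two numbers and separated from compound 1 by a gap beyond the usual scatter. Compound 3, `Cc1cc(-c2ccco2)nn1S(=O)(=O)Oc1ccccc1`, differs from compound 2 in one place: furan-2-yl in place of 3-methylphenyl on an aromatic carbon. Within the data shown here, no measured pair shows this kind of change, so there is no step to lean on. The step is expected to stay within the scatter: a number 6.3 percentage points higher from compound 2 to compound 3 (within the scatter). Compound 3 is estimated at 15%, within a range from 0% to 40%.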

Compound 3, a percentage reported as inhibition, in the whole organism at one dose (the size of the read-out at that dose, not a potency): 12.5%
Compound 3: middle estimate off by 2.5 percentage points, on the high side; low and high end bracket the measured number.
By their numbers in this assay, from the lowest: compounds 2 and 3 (each within the scatter of the next); then compound 1.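

In this assay, furan-2-yl in place of 3-methylphenyl gives a number 3.8 percentage points higher from compound 2 to compound 3 (within the scatter). At this aromatic carbon, then, a five-membered aromatic ring with 1 hetero atom and a six-membered aromatic ring of carbon only give numbers that cannot be told apart at this dose. No outside evidence bears on this result. Still open, on these data alone, is what a non-aromatic group on this same carbon, such as an amine or a carboxylic acid, would give in this assay.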